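This account rests on a few compounds, and the source may have more. Where it says the series, first, only, none or still open, it means among the compounds named here.

Compound 1 `COc1cc(-n2ncnc2-c2ccc(C)cc2)cc(OC)c1OC` gives 250 nM in a functional assay on HeLa cells (Homo sapiens) for antiproliferative activity, read by MTT assay, with a stated time of 72 h; a lower number here means a stronger inhibitor, a higher number a weaker inhibitor. Compound 2 `COc1cc(-n2ncnc2-c2cccc(F)c2)cc(OC)c1OC` yields in this assay only a limit, > 10000 nM. The change between them brought an at least 40-fold higher number from compound 1 to compound 2 (1.60 log units; beyond the scatter), so compound 2 stands at the limit of > 10000 nM in this assay, at which 1 of the 2 values shown sits, the weaker of the two values shown. Compound 3 `COc1cc(-n2ncnc2-c2cccc(Cl)c2)cc(OC)c1OC` differs from compound 2 by chloro in place of fluoro on an aromatic carbon. No measured step covers an exchange of this kind, and the single step shown concerns a different group, so for compound 3 a step of an at least 1.1-fold lower number from compound 2 to compound 3 (0.04 log units; that floor lies within the scatter) is expected, one that may well stay within the scatter. Compound 3 is therefore estimated at 9000 nM, within a range from 2500 nM to 30000 nM.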

Compound 3, half-maximal inhibitory concentration: > 10000 nM
Compound 3 ended at the assay's limit; the forecaster's own chance of this, stated with the estimate: 60%; at least 1.1-fold (0.04 log units) between middle value and limit.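

In this assay compound 3 gives > 10000 nM, which is a limit of the assay and not a number. The exchange of 4-methylphenyl for 3-chlorophenyl brings an at least 40-fold higher number from compound 1 to compound 3 (1.60 log units; beyond the scatter), so the loss seen with 3-fluorophenyl also appears with a chloro group; the step between the two halogens cannot be read, both values being limits. The series now gathers at one end of the range: the limit of > 10000 nM in this assay, at which 2 of the 3 values shown sit.

Open, as far as these compounds go, is whether the 3-position or the halogen itself goes with this loss: a 3-methylphenyl or 4-chlorophenyl group would separate the two. From the compounds shown here alone, how an amine on this ring would behave also remains open.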